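Bromo in Place of Fluoro Near the Assay Limit

The source may report more compounds than this note shows. Statements on the series, on what has been measured and on what is new or still open speak of the compounds shown alone.

Among the measured compounds shown here, in a functional assay on HCT-15 cells (Homo sapiens) for antiproliferative activity, read by MTT assay, with a stated time of 72 h (on this read-out lower numbers stand for stronger inhibition and higher numbers for weaker inhibition), compound 2 (`COc1cc(-c2nccn2-c2ccc(F)cc2)cc(OC)c1OC`) gives 68600 nM, the only true number available so far. Compound 1 (`COc1cc(-c2nccn2Cc2ccccc2)cc(OC)c1OC`) reads > 100000 nM in this assay, which is a limit of the assay and not a number.

Compound 3 (`COc1cc(-c2nccn2-c2ccc(Br)cc2)cc(OC)c1OC`) differs from compound 2 by bromo in place of fluoro on an aromatic carbon, with bromo in place of fluoro on an aromatic carbon, para to a large group. For the measured compounds named here, only one measured step bears on this change, and only indirectly: an at least 1.4-fold lower number from compound 1 to compound 2 (0.16 log units; that floor lies within the scatter). That step replaces benzyl with 4-fluorophenyl and does not exchange one halogen for another, so it gives no measured size for the swap at hand. A step beyond the scatter is therefore not expected in this assay, and no direction is firmly favoured. The expectation starts from compound 2 at 68600 nM. For compound 3, the expected value is 55000 nM, with an estimated range of 20000 nM to 100000 nM. This estimate corresponds to an expected 1.2-fold lower number from compound 2 to compound 3 (0.10 log units; within the scatter).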

Compound 3, half-maximal inhibitory concentration: 11700 nM
Compound 3: the middle estimate sits 4.7-fold (0.67 log units) above what was measured, outside the stated range (below it).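

In this assay, bromo in place of fluoro on an aromatic carbon, para to a large group, gives a 5.9-fold lower number from compound 2 to compound 3 (0.77 log units; beyond the scatter). Among the compounds shown here, the earlier compounds offered only an at least 1.4-fold lower number from compound 1 to compound 2 (0.16 log units; that floor lies within the scatter), a step that replaced benzyl with 4-fluorophenyl and left the halogen untouched, so this is the first measured sign that the exchange of one halogen for another at this carbon can by itself move the number beyond the scatter. Measured against the benzyl compound, the result is an at least 8.5-fold lower number from compound 1 to compound 3 (0.93 log units; beyond the scatter), which gives a floor and not a full size: the limit of > 100000 nM in this assay, at which 1 of the 3 values shown sits.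

The compounds shown carry only fluoro and bromo at this carbon, so it stays open how chloro, iodo, a methoxy group or an amine would read there, and whether the number follows any order among the halogens. They also leave open whether the same exchange would carry over to a 4-bromobenzyl group on the aromatic nitrogen, where the benzyl compound offers only a limit to compare with.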